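Halogen on the benzyl group: what to expect for compound 4

This account rests on a few compounds, and the source may have more. Where it says the series, first, only, none or still open, it means among the compounds named here.

Measured in a functional assay on MCF7 cells (Homo sapiens) for inhibition, read by MTT assay, with a stated time of 48 h, tested at 10 uM (a higher number here means more inhibition of growth at the concentration tested, a lower number less inhibition of growth), so far:
compound 1 `O=C(/C=C/c1ccc(OCc2cn(Cc3ccccc3)nn2)cc1)c1ccc(Br)cc1` gives 34%
compound 2 `O=C(/C=C/c1ccc(OCc2cn(Cc3cccc(Br)c3)nn2)cc1)c1ccc(Br)cc1` gives 36%
compound 3 `O=C(/C=C/c1ccc(OCc2cn(Cc3ccccc3F)nn2)cc1)c1ccc(Br)cc1` gives 38%

Compound 1 carries the unsubstituted benzyl group and stands lowest of the three numbers. Its nearest neighbour is compound 2, a number 2 percentage points higher from compound 1 to compound 2 (within the scatter), and the furthest is compound 3, a number 4 percentage points higher from compound 1 to compound 3 (within the scatter); both steps lie within the scatter, so the three compounds cannot be told apart on these data. The step between the two substituted compounds, a number 2 percentage points higher from compound 2 to compound 3 (within the scatter), is likewise within the scatter.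

Compound 4 `O=C(/C=C/c1ccc(OCc2cn(Cc3cccc(F)c3)nn2)cc1)c1ccc(Br)cc1` differs from compound 1 by fluoro in place of hydrogen on an aromatic carbon. Among the compounds with values here, the steps that bear on this change are those from compound 1 to compound 2 (bromo in place of hydrogen on the same ring) and from compound 1 to compound 3 (fluoro in place of hydrogen on that ring): a halogen entering the benzyl ring has so far moved the number by an amount within the scatter in each case. For this assay no step beyond the scatter is therefore expected; the estimated change is a number 2 percentage points higher from compound 1 to compound 4 (within the scatter).

Compound 4 is expected to give 36% in this assay, with a range from 26% to 46%.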

Compound 4, percent growth inhibition at one concentration: 42%
Compound 4: middle estimate off by 6 percentage points, on the low side, within the range that was stated.
By their numbers in this assay, from the lowest: compounds 1, 2, 3 and 4 (each within the scatter of the next).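

With benzyl changed to 3-fluorobenzyl, this assay shows a number 8 percentage points higher from compound 1 to compound 4 (within the scatter) and this is the largest step yet seen on this ring, but even so a halogen here gives no change that can be told from the scatter. Neither the place of the fluoro group nor the kind of halogen separates the compounds, with 3-fluorophenyl in place of 2-fluorophenyl giving a number 4 percentage points higher from compound 3 to compound 4 (within the scatter) and fluoro in place of bromo giving a number 6 percentage points higher from compound 2 to compound 4 (within the scatter) in the same assay. The data in hand offer no explanation for the size of these steps.

From the compounds shown here alone, since only hydrogen, bromo and fluoro appear on the benzyl ring, it remains open whether a different kind of group there, such as an amine, a carboxylic acid or a longer chain, would produce a step beyond the scatter. Also open, going by these compounds, is whether the same flat picture would hold at other concentrations, since each compound is read at a single concentration in this assay and the rest of the shared core stays unchanged throughout.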